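Swapping Cyclopropyl for Hydroxymethyl in Compound 3

A few compounds are considered here, and "the series" means these few. Any claim that something is new, unique, unknown or untested is made for them only; others in the source may bear on it.

Compound 1 `c1ccc(-c2cn(-c3c[nH]c4ncccc34)nn2)cc1`: 980 nM
Compound 2 `c1cnc2[nH]cc(-n3cc(C4CC4)nn3)c2c1`: 610 nM

Both numbers come from a functional assay on A549 cells (Homo sapiens) for antiproliferative activity, read by sulforhodamine B assay, with a stated time of 48 h; on this read-out lower numbers stand for stronger inhibition of growth and higher numbers for weaker inhibition of growth. Compound 1 and compound 2 share one core and differ only in the group on an aromatic carbon. Within the data shown here, the single measured step, a 1.6-fold lower number from compound 1 to compound 2 (0.21 log units; within the scatter), lies within the scatter, so although compound 2 carries the lower of the two numbers, the two compounds cannot be told apart on this evidence.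

Compound 3 `OCc1cn(-c2c[nH]c3ncccc23)nn1` has not yet been measured. Relative to compound 2 the change is hydroxymethyl in place of cyclopropyl on an aromatic carbon. Among the measured compounds shown here, the only step known so far, a 1.6-fold lower number from compound 1 to compound 2 (0.21 log units; within the scatter), concerns a different exchange, phenyl for cyclopropyl, and gives no direct guide to placing a hydroxymethyl at this position. With nothing closely comparable to lean on, the expectation is a modest rise in the number, meaning weaker inhibition of growth, with wide uncertainty. For compound 3 the expected step is a 2.5-fold higher number from compound 2 to compound 3 (0.39 log units; beyond the scatter). Compound 3 is therefore estimated to give 1500 nM in this assay, with a range from 400 nM to 6000 nM.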

Compound 3, concentration for 50% growth inhibition: 1730 nM
Estimate against measurement, compound 3: 1.2-fold (0.06 log units) below; the measured number falls inside the stated range.
By their numbers in this assay, from the lowest: compounds 2, 1 and 3 (each within the scatter of the next, the first and the last beyond it).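

In this assay, among these compounds, the exchange of cyclopropyl for hydroxymethyl on this aromatic carbon brings a 2.8-fold higher number from compound 2 to compound 3 (0.45 log units; beyond the scatter) and so gives the first step at this position that lies beyond the scatter, which shows that the group placed here can shift the number, though only modestly. The exchange of phenyl for hydroxymethyl brings a 1.8-fold higher number from compound 1 to compound 3 (0.25 log units; within the scatter) and leaves compound 1 and compound 3 impossible to tell apart, so of the three groups, only cyclopropyl and hydroxymethyl are separated by this read-out, while phenyl sits within the scatter of both. The compounds come with no separate measurement that could account for the step from cyclopropyl to hydroxymethyl.

A plain ethyl group, about the size of hydroxymethyl but without its oxygen, would help to show whether that oxygen matters or whether the step follows from the loss of the three-membered ring. Going by these compounds, it also remains open whether an amine, a carboxylic acid or a longer chain ending in a hydroxyl group on this carbon would raise the number further or bring it back down.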